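The compounds below may be only part of what the source reports. "The series", "measured", "known", "first", "only" and "open" are said of these compounds alone.

Measured so far in a functional assay on MGC-803 cells (Homo sapiens) for inhibition, read by MTT assay, with a stated time of 48 h; a lower number here means a stronger inhibitor, a higher number a weaker inhibitor:
compound 1, `O=C(NC(=S)Nc1ccc(Cl)c(-c2nc3ccccc3[nH]2)c1)c1ccc(OCc2ccc(Cl)c(Cl)c2)cc1`: 5170 nM
compound 2, `O=C(NC(=S)Nc1ccc(Cl)c(-c2nc3ccccc3[nH]2)c1)c1ccc(OCc2ccc(Cl)cc2Cl)cc1`: 3030 nM
compound 3, `Cc1ccc(NC(=O)NC(=O)c2ccc(OCc3ccc(Cl)c(Cl)c3)cc2)cc1-c1nc2ccccc2[nH]1`: 6080 nM

Compound 1 and compound 2 share one core, while compound 3 is built on a second core; the difference between the two cores is not broken down here. Compound 1 and compound 2 differ in one place only: 2,4-dichlorophenyl in place of 3,4-dichlorophenyl on a saturated chain carbon bound to an oxygen on an aromatic ring. This change gave a 1.7-fold lower number from compound 1 to compound 2 (0.23 log units; within the scatter).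

Compound 4, `Cc1ccc(NC(=O)NC(=O)c2ccc(OCc3ccc(Cl)cc3Cl)cc2)cc1-c1nc2ccccc2[nH]1`, has not yet been measured in this assay. It stands to compound 3 as compound 2 stands to compound 1, differing by 2,4-dichlorophenyl in place of 3,4-dichlorophenyl on a saturated chain carbon bound to an oxygen on an aromatic ring. The place of the change is the same in both pairs, so it is the same change carried onto the second core.

Going by the values given here, only one earlier instance of this change is available to rest an expectation on. The step from compound 3 to compound 4 in this assay is therefore expected to be a 1.6-fold lower number from compound 3 to compound 4 (0.20 log units; within the scatter), because a 1.7-fold lower number from compound 1 to compound 2 (0.23 log units; within the scatter) was seen on the first core. Compound 4 is expected to give 3800 nM, with a likely range from 1800 nM to 7600 nM.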

Compound 4, half-maximal inhibitory concentration: 2740 nM
Compound 4: middle estimate off by 1.4-fold (0.14 log units), on the high side; the measured number falls inside the stated range.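

In this assay, putting 2,4-dichlorophenyl in place of 3,4-dichlorophenyl on the second core gave a 2.2-fold lower number from compound 3 to compound 4 (0.35 log units; beyond the scatter). Set beside the same change on the core of compound 1, this step does not differ from the earlier one: the same change on two cores in this assay, a 1.7-fold lower number (0.23 log units; within the scatter) from compound 1 to compound 2 and a 2.2-fold lower number (0.35 log units; beyond the scatter) from compound 3 to compound 4, 1.3-fold (0.11 log units) apart, within the scatter of two such steps. Going by these compounds alone, the change therefore carried from one core to the other with a similar outcome, but this rests on only two pairs in a single cell assay, the step on the core of compound 1 does not by itself go beyond the scatter, and neither pair explains why the numbers moved or shows that the change would carry onto any further core.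

The compounds shown leave open whether a phenyl ring bearing a single chlorine, a trifluoromethyl group or a methoxy group would give a different number from the two dichlorophenyl groups. They also leave open what a longer chain between the oxygen and that ring would do on either core.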